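Adding methoxy to the benzoyl group of compound 3

The source may report more compounds than this note shows. Statements on the series, on what has been measured and on what is new or still open speak of the compounds shown alone.

Compound 1 (`COc1ccc(S(=O)(=O)N2CCc3cccc(NC(=O)Oc4ccccc4)c32)cc1`) gives > 10000 nM as a limit of the assay
Compound 2 (`COc1ccc(S(=O)(=O)N2CCc3cccc(NC(=O)c4ccncc4)c32)cc1`) gives 9.6 nM
Compound 3 (`COc1ccc(S(=O)(=O)N2CCc3cccc(NC(=O)c4ccccc4)c32)cc1`) gives 297 nM

All three were tested in a functional assay on KB cells (Homo sapiens) for cytotoxicity (on this read-out higher numbers stand for weaker inhibition and lower numbers for stronger inhibition), and no other read-out is at hand. Of the two true numbers, compound 3 holds the higher one, with a 31-fold higher number from compound 2 to compound 3 (1.49 log units; beyond the scatter) as the gap. Compound 4 (`COc1ccc(C(=O)Nc2cccc3c2N(S(=O)(=O)c2ccc(OC)cc2)CC3)cc1`) differs from compound 3 at one place (methoxy in place of hydrogen on an aromatic carbon) which turns phenyl into 4-methoxyphenyl. Going by the values given here, no measured step makes this exact change. The closest are swaps of the whole group on the carbonyl carbon, and all were large: an at least 33-fold lower number from compound 1 to compound 3 (1.52 log units; beyond the scatter) and an at least 1000-fold lower number from compound 1 to compound 2 (3.01 log units; beyond the scatter) as well as a 31-fold higher number from compound 2 to compound 3 (1.49 log units; beyond the scatter) in the comparison above. They show that this part of the series can move the read-out a long way. Compound 4 keeps the phenyl ring, however, so a much smaller change is expected, with no firm direction and probably nothing beyond the scatter. The expected change is a 1.2-fold lower number from compound 3 to compound 4 (0.07 log units; within the scatter) in this estimate. Compound 4 is estimated at 250 nM with an expected range from 40 nM to 1500 nM in this assay.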

Compound 4, half-maximal inhibitory concentration: 2600 nM
Compound 4: middle estimate off by 10-fold (1.02 log units), on the low side; measured number above the stated range.
By their numbers in this assay, from the lowest: compound 2; then compound 3; then compound 4. At a limit, above all of these: compound 1.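

In this assay, adding one methoxy to the phenyl ring, para to a large group, gives an 8.8-fold higher number from compound 3 to compound 4 (0.94 log units; beyond the scatter), so this ring responds to a small addition and not only to swaps of the whole group on the carbonyl carbon. With 4-methoxyphenyl in place of pyridin-4-yl, the step is a 270-fold higher number from compound 2 to compound 4 (2.43 log units; beyond the scatter), which is a large one. Compound 1 stands at a limit, and the step of an at least 3.8-fold lower number from compound 1 to compound 4 (0.58 log units; beyond the scatter) can be read only as a bound: the limit of > 10000 nM in this assay, at which 1 of the 4 values shown sits.

The compounds shown do not tell whether the weaker inhibition belongs to methoxy in particular or would follow from any group at this place on the ring. A fluorine, a methyl or a hydroxyl there would separate these readings, and methoxy on the pyridin-4-yl ring remains an open case.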